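This account rests on a few compounds, and the source may have more. Where it says the series, first, only, none or still open, it means among the compounds named here.

Two analogues of the shared core are in hand. Compound 1 `Nc1ncc(-c2cnn(C3CCNCC3)c2)cc1-c1nc2ccc(Nc3cc(C(F)(F)F)cc(C(F)(F)F)c3)cc2o1` gives 4200 nM in an assay on isolated protein for inhibition of G protein-coupled receptor kinase 5 (Homo sapiens), read by TR-FRET, with stated times of 10 min and 1 h (a lower number here means a stronger inhibitor, a higher number a weaker inhibitor), and compound 2 `Nc1ncc(-c2cnn(C3CCNCC3)c2)cc1-c1nc2ccc(Nc3ccc(F)cc3)cc2o1` gives 3700 nM in this assay; the two numbers lie within the scatter of each other, so neither is set apart. Compound 3 `Nc1ncc(-c2cnn(C3CCNCC3)c2)cc1-c1nc2ccc(Oc3ccccc3)cc2o1` carries phenoxy in place of (4-fluorophenyl)amino on an aromatic carbon. The change on the aryl group from compound 1 to compound 2 left the number essentially unchanged, so no step beyond the scatter is expected for compound 3 in this assay, with some allowance for a weaker result. The expected step of a 1.4-fold higher number from compound 2 to compound 3 (0.13 log units; within the scatter) is small. For compound 3 the estimate is 5000 nM, between 2000 nM and 15000 nM.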

Compound 3, half-maximal inhibitory concentration: 4000 nM
Compound 3: the middle estimate sits 1.3-fold (0.10 log units) above what was measured; low and high end bracket the measured number.
By their numbers in this assay, from the lowest: compounds 2, 3 and 1 (each within the scatter of the next).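

Swapping (4-fluorophenyl)amino for phenoxy on this aromatic carbon gives a 1.1-fold higher number from compound 2 to compound 3 (0.03 log units; within the scatter) in this assay. Going by these compounds alone, the first change here to the atom linking the aryl group to the shared core, it takes the group from 1 hydrogen-bond donor to 0 and removes the fluorine, yet the number does not move beyond the scatter. Nothing available accounts for this flat result.

All three compounds carry an aryl group at this carbon, and their numbers lie within the scatter of each other. On these data alone, how a small amine, a carboxylic acid or a longer chain would read at this carbon remains open.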